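The source may report more compounds than this note shows. Statements on the series, on what has been measured and on what is new or still open speak of the compounds shown alone.

In a functional assay on ECa-109 cells for inhibition, with ECa-109 cell line (Homo sapiens) as the target, read by sulforhodamine B assay (on this read-out lower numbers stand for stronger inhibition and higher numbers for weaker inhibition), compound 1 `O=C1C(Nc2ccc(I)cc2)=CC(=O)c2c1nc1n2[C@H]2OC[C@@H](O)[C@H]2OC1` gives 2530 nM. Compound 2 `Cc1ccc(NC2=CC(=O)c3c(nc4n3[C@H]3OC[C@@H](O)[C@H]3OC4)C2=O)cc1` reads > 4000 nM, which is a limit. Compound 3 `O=C1C(N2CCCC2)=CC(=O)c2c1nc1n2[C@H]2OC[C@@H](O)[C@H]2OC1` reads > 16000 nM, also a limit, so it stands only as a limit. Compound 4 `COc1ccc(NC2=CC(=O)c3c(nc4n3[C@H]3OC[C@@H](O)[C@H]3OC4)C2=O)cc1` carries (4-methoxyphenyl)amino in place of pyrrolidin-1-yl on a double-bonded ring carbon. The nearest evidence is the opposite exchange, with an at least 6.3-fold higher number from compound 1 to compound 3 (0.80 log units; beyond the scatter). The other two steps help less: a step that the two limits leave unreadable from compound 2 to compound 3, and an at least 1.5-fold higher number from compound 1 to compound 2 (0.19 log units; that floor lies within the scatter). A move back to an arylamino group is therefore expected to lower the number, by a modest step beyond the scatter. The expected step is an at least 3.2-fold lower number from compound 3 to compound 4 (0.50 log units; beyond the scatter). For compound 4 the estimated value is 5000 nM, with an expected range from 2000 nM to 16000 nM.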

Compound 4, half-maximal inhibitory concentration: 3410 nM
Compound 4: the middle estimate sits 1.5-fold (0.17 log units) above what was measured; measured number inside the range.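

The gain of an arylamino group over pyrrolidin-1-yl on the double-bonded ring carbon now rests on a second measured compound, with an at least 4.6-fold lower number from compound 3 to compound 4 (0.67 log units; beyond the scatter). Compound 3 is only a limit: the limit of > 16000 nM in this assay, at which 1 of the 4 values shown sits. On the aromatic carbon, methoxy and iodo cannot be told apart, with a 1.3-fold higher number from compound 1 to compound 4 (0.13 log units; within the scatter), and the floor for methoxy against methyl, an at least 1.1-fold lower number from compound 2 to compound 4 (0.06 log units; that floor lies within the scatter), adds nothing further.

Compound 2 is also only a limit: the limit of > 4000 nM in this assay, at which 1 of the 4 values shown sits. Going by these compounds, how far methoxy truly lies from methyl stays open, as does whether a carboxylic acid or a dimethylamino group on the aromatic carbon would change the reading.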